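This account rests on a few compounds, and the source may have more. Where it says the series, first, only, none or still open, it means among the compounds named here.

In a functional assay on MOLT-4 cells (Homo sapiens) for antiproliferative activity, read by cell counting, with a stated time of 2 days (on this read-out lower numbers stand for stronger inhibition and higher numbers for weaker inhibition), compound 1 (`COc1ccc(Nc2nc(N)c(C(=O)c3ccccc3)s2)cc1`) gives 230 nM as the higher of the two true numbers. Compound 3 (`COc1cc(C(=O)c2sc(Nc3ccc(Cl)cc3)nc2N)cc(OC)c1OC`) sits lower with 110 nM in the same read-out. Compound 2 (`Nc1nc(Nc2ccc(Cl)cc2)sc1C(=O)c1ccccc1`) reports only > 10000 nM and this is a limit. Compound 4 (`COc1ccc(Nc2nc(N)c(C(=O)c3ccc([N+](=O)[O-])cc3)s2)cc1`) departs from compound 1 by nitro in place of hydrogen on an aromatic carbon as nitro in place of hydrogen on an aromatic carbon, para to a large group. Among the measured compounds shown here, the sole measured step (an at least 43-fold higher number from compound 1 to compound 2 (1.63 log units; beyond the scatter)) is large, but it is chloro in place of methoxy elsewhere in the molecule, so it sets no direct size here. A moderate rise is estimated in this assay as a 3.5-fold higher number from compound 1 to compound 4 (0.54 log units; beyond the scatter) toward weaker inhibition. Compound 4 is expected at 800 nM with an estimated range from 120 nM to 6000 nM overall.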

Compound 4, half-maximal inhibitory concentration: 29 nM
Compound 4: middle estimate off by 28-fold (1.44 log units), on the high side, outside the stated range (below it).
By their numbers in this assay, from the lowest: compound 4; then compound 3; then compound 1. At a limit, above all of these: compound 2.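

In this assay, nitro in place of hydrogen on the six-membered aromatic ring of carbon only, para to a large group, gives a 7.9-fold lower number from compound 1 to compound 4 (0.90 log units; beyond the scatter), so this position accepts a substituent with a gain in inhibition. The earlier step, an at least 43-fold higher number from compound 1 to compound 2 (1.63 log units; beyond the scatter), was a change elsewhere in the molecule and went the other way. Nothing measured here gives a reason for this gain. Whether the gain is particular to nitro stays open, since the compounds shown include no amine or carboxylic acid at this position. Also open, from the compounds shown here alone, is whether it would hold with chloro in place of methoxy.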